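The compounds below may be only part of what the source reports. "The series", "measured", "known", "first", "only" and "open" are said of these compounds alone.

Three compounds have been measured in a functional assay on K562 cells (Homo sapiens) for cytotoxicity, read by trypan blue exclusion, with a stated time of 96 h; a lower number here means a stronger inhibitor, a higher number a weaker inhibitor:

Compound 1 `COc1ccc(CS(=O)(=O)/C=C/c2c(F)cc(F)cc2F)cc1N` gives 800 nM
Compound 2 `COc1ccc(CS(=O)(=O)/C=C/c2c(OC)cccc2OC)cc1N` gives 50 nM
Compound 3 `COc1ccc(CS(=O)(=O)/C=C/c2cc(OC)c(OC)c(OC)c2)cc1N` gives 250 nM

Among these three, compound 3 at 250 nM stands in the middle. Its number is lower than that of compound 1 and higher than that of compound 2, and both gaps lie beyond the usual scatter of repeated measurements.

The next compound to be tested is compound 4 `COc1ccc(CS(=O)(=O)/C=C/c2cc(OC)c(OC)c(OC)c2)cc1NCC(=O)O`, which keeps everything in compound 3 except at one place. The change is carboxymethyl in place of hydrogen on a nitrogen on an aromatic ring, so carboxymethyl replaces hydrogen on a nitrogen on an aromatic ring, and the amino group becomes a (carboxymethyl)amino group.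

Among the measured compounds shown here, none of the measured compounds differ from one another in only one place, so the data offer no direct precedent for the size of this step. The three measured compounds do show that changes elsewhere in the structure can move the number well beyond the scatter. A moderate loss of potency is the expectation here, with a weaker result more likely than a stronger one, though this is a judgement and not a measured trend. The expected change is a 2.8-fold higher number from compound 3 to compound 4 (0.45 log units; beyond the scatter) in this assay and may prove only slightly larger than the scatter. The estimate for compound 4 is 700 nM, with an expected range from 150 nM to 3000 nM as its likely bounds.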

Compound 4, half-maximal inhibitory concentration: 3000 nM
For compound 4 the middle estimate is 4.3-fold (0.63 log units) below the measured one, and the stated range covers the measured number.
By their numbers in this assay, from the lowest: compound 2; then compound 3; then compound 1; then compound 4.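

In this assay, among the compounds shown here, this is the first change in one place only, and it is large: a 12-fold higher number from compound 3 to compound 4 (1.08 log units; beyond the scatter) when carboxymethyl replaces hydrogen on the nitrogen on the aromatic ring. The earlier compounds shown here could not show this, since none differed from another in one place only; the result shows that the number responds strongly to this change at this nitrogen, and that here the unsubstituted amino group goes with the lower number. No measurement given here accounts for the size of the step.

A single substituent cannot separate the contribution of the carboxylic acid from that of the added chain or from substitution of the nitrogen as such; a methyl group, an acetyl group, the methyl ester or primary amide of the same acid, or a longer chain ending in a carboxylic acid on this nitrogen would each help to tell these apart. Going by these compounds, it also remains open whether the same change would have a similar effect on the core of compound 1 or compound 2, where the other end of the molecule carries different groups.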